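This account rests on a few compounds, and the source may have more. Where it says the series, first, only, none or still open, it means among the compounds named here.

Measured compounds in the series so far:

Compound 1, `O[C@@H]1Cc2ccccc2[C@H]1NC1CCN(CCCc2c[nH]c3ccc(-n4cnnc4)cc23)CC1` — 6.6 nM
Compound 2, `OC[C@H](NC1CCN(CCCc2c[nH]c3ccc(Cn4cncn4)cc23)CC1)c1ccccc1` — 23 nM
Compound 3, `C[C@@H](NC1CCN(CCCc2c[nH]c3ccc(-n4ccnc4)cc23)CC1)c1ccccc1` — 4.2 nM

In an assay on CHO cells for displacement of a labelled ligand from 5-hydroxytryptamine receptor 1D (Homo sapiens) (on this read-out lower numbers stand for stronger inhibition and higher numbers for weaker inhibition), compound 1 sits with the second highest of the three numbers. Its nearest neighbour is compound 3, whose value lies within the usual scatter of that of compound 1, so no order between the two can be read. Compound 2 stands furthest away, with a higher number beyond the scatter.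

The next compound to be tested is compound 4, `CN(Cc1ccco1)C1CCN(CCCc2c[nH]c3ccc(-n4cnnc4)cc23)CC1`. It differs from compound 1 in one place: ((furan-2-yl)methyl)(methyl)amino in place of (2-hydroxy-2,3-dihydro-1H-inden-1-yl)amino on a saturated ring carbon. The two hydrogen-bond donors of the leaving group are gone, and the entering group is smaller.

Among the measured compounds shown here, no single-point step between measured compounds is available to calibrate this change, and nothing among the three values bears directly on the entering group. The expectation for compound 4 is a step of a 3.0-fold higher number from compound 1 to compound 4 (0.48 log units; beyond the scatter) towards a higher number in this assay, modest but likely beyond the scatter. Compound 4 is therefore estimated at 20 nM, with a range from 5 nM to 80 nM.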

Compound 4, half-maximal inhibitory concentration: 9.3 nM
Estimate against measurement, compound 4: 2.2-fold (0.33 log units) above; the range from low to high includes it.
By their numbers in this assay, from the lowest: compounds 3, 1 and 4 (each within the scatter of the next, the first and the last beyond it); then compound 2.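

In this assay, the exchange on the saturated ring carbon gives a 1.4-fold higher number from compound 1 to compound 4 (0.15 log units; within the scatter) and so leaves no readable difference between ((furan-2-yl)methyl)(methyl)amino and (2-hydroxy-2,3-dihydro-1H-inden-1-yl)amino at this position. This single pair shows that the position tolerates losing both hydrogen-bond donors and both defined stereocentres, and going from 11 heavy atoms to 8, without a step beyond the scatter. No independent evidence bears on this result.

Going by these compounds, the donors, the ring type and the size all change together in this one step, so the contribution of each stays open. Also open, on these data alone, is how a smaller group at this carbon, such as dimethylamino, would read against compound 1 and compound 4.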